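Methylating the Ring Nitrogen of Compound 1

This account rests on a few compounds, and the source may have more. Where it says the series, first, only, none or still open, it means among the compounds named here.

Compounds measured so far in a functional assay on A549 cells (Homo sapiens) for antiproliferative activity, read by MTT assay, with a stated time of 72 h; on this read-out lower numbers stand for stronger inhibition and higher numbers for weaker inhibition:
compound 1, `O=C(Nc1ccc(Oc2ccnc3[nH]ccc23)cc1)c1cc2cccnc2n(-c2ccccc2)c1=O`, 360 nM
compound 2, `COc1ccc(-n2c(=O)c(C(=O)Nc3ccc(Oc4ccnc5[nH]ccc45)cc3)cc3cccnc32)cc1`, 930 nM

Compound 1 holds the lowest of the two numbers in this assay. Among the measured compounds shown here, its nearest neighbour is compound 2, and the single measured step shows a 2.6-fold higher number from compound 1 to compound 2 (0.41 log units; beyond the scatter), a change that sits on an aromatic carbon of the phenyl ring on the core.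

Compound 3, `Cn1ccc2c(Oc3ccc(NC(=O)c4cc5cccnc5n(-c5ccccc5)c4=O)cc3)ccnc21`, is not yet measured. It differs from compound 1 by methyl in place of hydrogen on an aromatic nitrogen. For the measured compounds named here, no measured step touches this ring nitrogen: the only step available, from compound 1 to compound 2, alters a different part of the molecule and is of modest size, so it gives no direct guide to the effect of removing the hydrogen from the five-membered ring. Going by the values given here, the expectation must therefore rest on the width of the scatter and on the modest size of the one known step. Compound 3 is expected to show a modest increase, a 1.9-fold higher number from compound 1 to compound 3 (0.29 log units; within the scatter), with a value estimated at 700 nM, in a range from 200 nM to 2500 nM.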

Compound 3, half-maximal inhibitory concentration: 850 nM
Beside the measured number, compound 3's estimate is 1.2-fold (0.08 log units) below it; the measured number falls inside the stated range.
By their numbers in this assay, from the lowest: compound 1; then compounds 3 and 2 (each within the scatter of the next).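

In this assay, among the compounds shown here, the step of a 2.4-fold higher number from compound 1 to compound 3 (0.37 log units; beyond the scatter) is the first reading at the aromatic nitrogen of the five-membered aromatic ring, a second place on compound 1, and it shows that this hydrogen can be replaced by methyl at a modest cost in the number. Compound 3 at 850 nM still inhibits A549 cells, so the free hydrogen on this nitrogen is not needed for a sub-micromolar-range reading, and this change resembles in size the earlier step of a 2.6-fold higher number from compound 1 to compound 2 (0.41 log units; beyond the scatter) made at an aromatic carbon, with both changes to compound 1 moving the number the same way. Nothing measured here accounts for why the number moves at this nitrogen.

As far as these compounds go, whether a larger group on this nitrogen, such as an ethyl group or a longer chain ending in an amine, would move the number further remains open. Also open, from the compounds shown here alone, is whether the methyl on this nitrogen and the methoxy of compound 2 would act independently if they stood together in one molecule.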